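The compounds below may be only part of what the source reports. "The series", "measured", "known", "first", "only" and "open" are said of these compounds alone.

In a functional assay on L1210 cells (Mus musculus) (on this read-out higher numbers stand for an effect only at larger amounts of compound and lower numbers for an effect already at smaller amounts), compound 1 `Nc1ncn(C[C@@H]2CO[C@H](CO)O2)c(=O)n1` gives 70000 nM, and compound 2 `Nc1ncn(C[C@H]2CO[C@H](CO)O2)c(=O)n1` gives 70000 nM, so these two stand level. Compound 3 `Cc1nn(C[C@H]2CO[C@H](CO)O2)c(=O)[nH]c1=O` reads > 100000 nM, which is a limit of the assay and not a number. Compound 4 `Nc1ncn(C[C@H]2CO[C@@H](CO)O2)c(=O)n1` is related to compound 2 by a change of shape alone: the two compounds have the same atoms and bonds and differ only in configuration as drawn: 1 of 2 stereo elements differ; a stereocentre at a saturated ring carbon is drawn S in compound 2 and R in compound 4. Going by the values given here, only one measured step is of this same kind, a switch in configuration with the atoms and bonds untouched, and it came out as no change at the digits printed from compound 1 to compound 2 (within the scatter). With that single precedent, no shift beyond the scatter is expected, so the estimated step is no change at the digits printed from compound 2 to compound 4 (within the scatter). For compound 4 the estimated value is 70000 nM, with an expected range of 25000 nM to 100000 nM.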

Compound 4, half-maximal effective concentration: 90000 nM
Compound 4: middle estimate off by 1.3-fold (0.11 log units), on the low side; the measured number falls inside the stated range.
By their numbers in this assay, from the lowest: compounds 1, 2 and 4 (each within the scatter of the next). At a limit, above all of these: compound 3.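

An earlier step inverted one stereocentre; this result inverts the other, and in this assay it reads as a 1.3-fold higher number from compound 2 to compound 4 (0.11 log units; within the scatter). Inverting both stereocentres at once, which gives the mirror image, reads as a 1.3-fold higher number from compound 1 to compound 4 (0.11 log units; within the scatter). Across compounds 1, 2 and 4, then, neither stereocentre moves the number beyond the scatter, whether inverted alone or together with the other. From the compounds shown here alone, what stays open is whether changing the atoms rather than the shape would shift the number, for example a carboxylic acid or a longer chain in place of the hydroxymethyl group.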